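The compounds below may be only part of what the source reports. "The series", "measured", "known", "first", "only" and "open" are said of these compounds alone.

Of the compounds shown here, three have so far been measured in a functional assay on the whole organism for inhibition, with Nicotiana tabacum as the target (on this read-out lower numbers stand for stronger inhibition and higher numbers for weaker inhibition), and a fourth awaits testing. Compound 1 `Cc1nc2nccc-2c(NC(C)C)[nH]1` gives 550000000 nM in this assay, the highest number of the three and hence the weakest inhibition. Compound 2 `Cc1nc(NC2CCC2)c2cc[nH]c2n1` gives 74100000 nM, the lowest number of the three. Compound 3 `Cc1nc(NC(C)(C)O)c2cc[nH]c2n1` gives 166000000 nM, between the other two. Among the measured compounds shown here, the one measured step between compounds that differ in a single place is a 2.2-fold higher number from compound 2 to compound 3 (0.35 log units; beyond the scatter); it swaps one group on a ring nitrogen for another and is modest in size.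

Compound 4 `Cc1nc2nccc-2c(NCC(C)C)[nH]1` keeps the core of compound 1 and differs from it only in that (isobutyl in place of isopropyl on a nitrogen on an aromatic ring). For the measured compounds named here, this change lengthens the chain on the nitrogen by one carbon without adding a ring, a donor or an acceptor, so it is a smaller alteration than the one seen from compound 2 to compound 3, and no measured step mirrors it directly. The expectation for this assay is therefore a step from compound 1 to compound 4 of about a 1.4-fold lower number from compound 1 to compound 4 (0.14 log units; within the scatter), which would lie within the scatter. On that basis compound 4 is estimated at 400000000 nM, with a likely range from 150000000 nM to 1100000000 nM.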

Compound 4, half-maximal inhibitory concentration: 38900000 nM
The estimate for compound 4 lay 10-fold (1.01 log units) above the measured number; measured number below the stated range.
By their numbers in this assay, from the lowest: compounds 4 and 2 (each within the scatter of the next); then compound 3; then compound 1.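

In this assay, the nitrogen on an aromatic ring in the core of compound 1 proves highly sensitive to the shape and size of a plain carbon chain: isobutyl, with 4 carbon atoms, in place of isopropyl, with 3, gives a 14-fold lower number from compound 1 to compound 4 (1.15 log units; beyond the scatter) and so much stronger inhibition. Neither group has a ring, a hydrogen-bond donor or acceptor, or a net charge, so this large shift comes from a swap between two simple carbon groups, and it is larger than a 2.2-fold higher number from compound 2 to compound 3 (0.35 log units; beyond the scatter) on another core. No separate measurement is available to explain how such a small structural change produces so large a step.

On these data alone, this is a single step on a single core, so it remains open whether a longer chain such as n-pentyl would extend the gain or lose it, and whether an amine or a carboxylic acid at the end of the chain would be tolerated. As far as these compounds go, it is also open whether isobutyl would bring a similar gain on the core of compound 2, where cyclobutyl occupies the same kind of nitrogen.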